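Removing the side-chain hydroxy in the fluorobenzyl series

The source may report more compounds than this note shows. Statements on the series, on what has been measured and on what is new or still open speak of the compounds shown alone.

Of the compounds shown here, three of the shared core have been measured in an assay on isolated protein for binding affinity to adenosine receptor A1 (Bos taurus); on this read-out lower numbers stand for stronger inhibition and higher numbers for weaker inhibition. Compound 1 `CCNc1nc(-c2ccccc2)nc2c1nnn2Cc1ccccc1Cl` gives 463000000 nM. Compound 2 `CCCCNc1nc(-c2ccccc2)nc2c1nnn2Cc1ccccc1F` gives 4300000 nM, and compound 3 `OCCNc1nc(-c2ccccc2)nc2c1nnn2Cc1ccccc1F` gives 54000000 nM. Compound 3 thus stands second highest of the three numbers, closest to compound 1 and furthest from compound 2.

Compound 4 `CCNc1nc(-c2ccccc2)nc2c1nnn2Cc1ccccc1F` is not yet measured. It differs from compound 3 by hydrogen in place of hydroxy on a saturated chain carbon, two bonds along the chain from a nitrogen on an aromatic ring. Among the compounds with values here, the one measured step that bears on this is the introduction of the hydroxy into the side chain, a 13-fold higher number from compound 2 to compound 3 (1.10 log units; beyond the scatter), which raised the number well beyond the scatter. Compound 4 reverses that introduction while keeping a shorter chain than compound 2, so the step is expected in the opposite direction, lowering the number, but probably not all the way back to compound 2. Within the data shown here, compound 1, which shares the ethylamino chain, carries chlorine rather than fluorine on the benzyl ring, and no single step connects it to compound 4.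

In this assay compound 4 is therefore expected to give 15000000 nM, within 3000000 nM to 80000000 nM, an expected step of a 3.6-fold lower number from compound 3 to compound 4 (0.56 log units; beyond the scatter).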

Compound 4, inhibition constant: 11000000 nM
Compound 4: middle estimate off by 1.4-fold (0.13 log units), on the high side; measured number inside the range.
By their numbers in this assay, from the lowest: compound 2; then compound 4; then compound 3; then compound 1.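

The hydroxy itself carries a cost in this assay: with the chain otherwise unchanged, hydrogen in place of hydroxy gives a 4.9-fold lower number from compound 3 to compound 4 (0.69 log units; beyond the scatter) and so separates this change from chain length, while hydrogen in place of ethyl at the same chain carbon gives a 2.6-fold higher number from compound 2 to compound 4 (0.41 log units; beyond the scatter) as a separate modest effect. The benzyl ring substituent matters more than either chain change here, since fluoro in place of chloro on an aromatic carbon gives a 42-fold lower number from compound 1 to compound 4 (1.62 log units; beyond the scatter) as a large step with the ethylamino chain held constant.

Open, from the compounds shown here alone, is whether a methoxy or an amine in place of the hydroxy on the chain would move the number in the same direction as the hydroxy. Also open, going by these compounds, is whether a longer chain than butyl continues the trend, and whether the step from chloro to fluoro keeps its size with the 2-hydroxyethyl chain. Nothing shown gives a measured reason for any of these steps.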